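From compound 3 to compound 4: a changed phenyl group

A few compounds are considered here, and "the series" means these few. Any claim that something is new, unique, unknown or untested is made for them only; others in the source may bear on it.

In a functional assay on K562 cells (Homo sapiens) for inhibition, read by MTT assay, with a stated time of 48 h (a lower number here means a stronger inhibitor, a higher number a weaker inhibitor), compound 1 (`Nc1ccc(-c2cn([C@@H]3CN[C@H](C(=O)Nc4ccc(Cl)c(C(F)(F)F)c4)C3)nn2)cn1`) gives 10400 nM, compound 2 (`CC(=O)Nc1n[nH]c2cc(-c3cn([C@@H]4CN[C@H](C(=O)Nc5ccc(Cl)c(C(F)(F)F)c5)C4)nn3)ccc12`) gives 15500 nM and compound 3 (`O=C(Nc1n[nH]c2cc(-c3cn([C@@H]4CN[C@H](C(=O)Nc5ccc(Cl)c(C(F)(F)F)c5)C4)nn3)ccc12)C1CC1`) gives 5200 nM. Compound 3 thus lies within the scatter of compound 1, and its number is the lower one against compound 2. Compound 4 (`O=C(Nc1n[nH]c2cc(-c3cn([C@@H]4CN[C@H](C(=O)Nc5ccc(Cl)cc5Cl)C4)nn3)ccc12)C1CC1`) has 2,4-dichlorophenyl in place of 4-chloro-3-(trifluoromethyl)phenyl on an amide-type nitrogen. For the measured compounds named here, no measured step touches this group. The only one, a 3.0-fold lower number from compound 2 to compound 3 (0.47 log units; beyond the scatter), is modest and swaps cyclopropyl for methyl on a carbonyl carbon, so it offers little guidance. No change beyond the scatter is therefore expected, and the estimated step is a 1.3-fold higher number from compound 3 to compound 4 (0.13 log units; within the scatter). For compound 4 the estimated value is 7000 nM, with an expected range from 2800 nM to 17000 nM.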

Compound 4, half-maximal inhibitory concentration: 5340 nM
Estimate against measurement, compound 4: 1.3-fold (0.12 log units) above, within the range that was stated.
By their numbers in this assay, from the lowest: compounds 3, 4, 1 and 2 (each within the scatter of the next, the first and the last beyond it).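

In this assay, the step of a 1.0-fold higher number from compound 3 to compound 4 (0.01 log units; within the scatter) shows that the aryl group on this amide-type nitrogen can change without a change in the number beyond the scatter, whereas the earlier step altered only the group on a carbonyl carbon. In this pair, the trifluoromethyl group is gone and 2,4-dichlorophenyl, the group with fewer heavy atoms, takes the place of 4-chloro-3-(trifluoromethyl)phenyl. Nothing available explains this result. From the compounds shown here alone, whether plain phenyl, or a phenyl ring carrying an amine or a carboxylic acid, would shift the number beyond the scatter remains open.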